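A few compounds are considered here, and "the series" means these few. Any claim that something is new, unique, unknown or untested is made for them only; others in the source may bear on it.

Measured compounds:
compound 1, `O=c1[nH]cc(S(=O)(=O)Nc2ccccc2-c2cn(-c3cccc(F)c3)nn2)c(=O)[nH]1`: > 20000 nM
compound 2, `O=c1[nH]cc(S(=O)(=O)Nc2ccccc2-c2cn(-c3ccc(F)cc3)nn2)c(=O)[nH]1`: > 20000 nM
compound 3, `O=c1[nH]cc(S(=O)(=O)Nc2cccc(-c3cn(-c4cccc(F)c4)nn3)c2)c(=O)[nH]1`: > 20000 nM

All three were tested in a functional assay on SGC-7901 cells (Homo sapiens) for antiproliferative activity, read by MTT assay, with a stated time of 24 h; on this read-out lower numbers stand for stronger inhibition and higher numbers for weaker inhibition. In this assay compound 1 gives > 20000 nM, which is a limit of the assay and not a number. Compound 2 gives > 20000 nM in this assay, again a limit. Compound 3 gives > 20000 nM in this assay, also a limit. Among the measured compounds shown here, every value shown therefore sits at the limit of > 20000 nM in this assay, at which 3 of the 3 values shown sit, so no compound can be set in order against another.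

Compound 1 and compound 2 differ by one change, (4-fluorophenyl in place of 3-fluorophenyl on an aromatic nitrogen). The step this makes is a step that the two limits leave unreadable from compound 1 to compound 2; both values rest on the limit, and the size of the step cannot be read from them. Compound 3 has the same atoms as compound 1 joined differently, and the difference between the two cores is not broken down here.

The unmeasured compound 4 is `O=c1[nH]cc(S(=O)(=O)Nc2cccc(-c3cn(-c4ccc(F)cc4)nn3)c2)c(=O)[nH]1`. It stands to compound 3 as compound 2 stands to compound 1: the change is 4-fluorophenyl in place of 3-fluorophenyl on an aromatic nitrogen, the same change, made at the same place in words.

The step from compound 3 to compound 4 is expected to be a step that the limit leaves unreadable from compound 3 to compound 4, since the measured pair carrying this change rests at the limit of > 20000 nM in this assay, at which 3 of the 3 values shown sit. Compound 4 is therefore expected to give about 30000 nM, somewhere between 12000 nM and 100000 nM, and most likely to be reported only as a limit again.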

Compound 4, half-maximal inhibitory concentration: > 20000 nM
Compound 4 ended at the assay's limit (the forecaster's own chance of this, stated with the estimate: 85%); the middle value lies beyond the limit too.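

In this assay compound 4 gives > 20000 nM, which is a limit of the assay and not a number. Among the compounds shown here, compound 3 also rests on a limit, so no step from it to compound 4 can be read, and the four compounds cannot be put in order: the limit of > 20000 nM in this assay, at which 4 of the 4 values shown sit. The compounds shown leave open whether 4-fluorophenyl and 3-fluorophenyl differ at all in this assay, and what change to these compounds would bring a value that can be read as a number.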